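Acyl aryl change on the shared core, compound 4

This account rests on a few compounds, and the source may have more. Where it says the series, first, only, none or still open, it means among the compounds named here.

Compound 1 `CN(C(=O)NC(=O)c1cccc(C(F)(F)F)c1)c1nc(C(F)(F)F)c(C(=O)N/N=C/c2ccc(C(F)(F)F)cc2)s1` holds the lowest number among the three measured compounds: in a functional assay on BCG823 cells (Homo sapiens) for inhibition, read by MTT assay, with a stated time of 72 h (on this read-out higher numbers stand for weaker inhibition and lower numbers for stronger inhibition), compound 1 gives 4.22 ug/mL. Compound 2 `CN(C(=O)NC(=O)c1cccc(C(F)(F)F)c1)c1nc(C(F)(F)F)c(C(=O)N/N=C/c2ccccc2C(F)(F)F)s1` gives 7.29 ug/mL in this assay, and compound 3 `CN(C(=O)NC(=O)c1c(F)cccc1F)c1nc(C(F)(F)F)c(C(=O)N/N=C/c2ccccc2C(F)(F)F)s1` gives 17 ug/mL. The step of a 1.7-fold higher number from compound 1 to compound 2 (0.24 log units; within the scatter) alters the aryl on the carbon with a double bond to nitrogen, whereas the step of a 2.3-fold higher number from compound 2 to compound 3 (0.37 log units; beyond the scatter) alters the aryl on the carbonyl carbon.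

Compound 4 `CN(C(=O)NC(=O)c1ccccc1F)c1nc(C(F)(F)F)c(C(=O)N/N=C/c2ccc(C(F)(F)F)cc2)s1` is not yet measured. It differs from compound 1 in one place: 2-fluorophenyl in place of 3-(trifluoromethyl)phenyl on a carbonyl carbon. Of the measured steps only a 2.3-fold higher number from compound 2 to compound 3 (0.37 log units; beyond the scatter) bears on this position; there a fluorinated phenyl in place of 3-(trifluoromethyl)phenyl on the carbonyl carbon gave a modest rise in the number. A step of similar size and in the same direction is therefore expected, though with one example only the size remains uncertain. Compound 4 is expected to give 8 ug/mL in this assay, within a range of 4 ug/mL to 17 ug/mL, corresponding to an expected step of a 1.9-fold higher number from compound 1 to compound 4 (0.28 log units; within the scatter).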

Compound 4, half-maximal inhibitory concentration: 3.87 ug/mL
The estimate for compound 4 lay 2.1-fold (0.32 log units) above the measured number; measured number below the stated range.
By their numbers in this assay, from the lowest: compounds 4, 1 and 2 (each within the scatter of the next); then compound 3.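

In this assay the change to 2-fluorophenyl in place of 3-(trifluoromethyl)phenyl on a carbonyl carbon gives a 1.1-fold lower number from compound 1 to compound 4 (0.04 log units; within the scatter) and so leaves no readable change with 4-(trifluoromethyl)phenyl on the carbon with a double bond to nitrogen. The rise seen in a 2.3-fold higher number from compound 2 to compound 3 (0.37 log units; beyond the scatter) therefore does not extend to every fluorinated phenyl at this position, and compound 4 goes against any such pattern. No measurement at hand accounts for this result.

The two steps differ both in the fluorinated phenyl and in the aryl on the carbon with a double bond to nitrogen, so the compounds shown cannot separate these two changes. Also open, from the compounds shown here alone, is how an aminophenyl, a carboxylic acid on the phenyl or a longer alkyl chain would read on this carbonyl carbon.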